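A few compounds are considered here, and "the series" means these few. Any claim that something is new, unique, unknown or untested is made for them only; others in the source may bear on it.

Measured so far in a functional assay on MCF cells (Homo sapiens) for antiproliferative activity, with a stated time of 72 h; on this read-out higher numbers stand for weaker inhibition and lower numbers for stronger inhibition:
Compound 1, `OC[C@H]1O[C@@H](n2cnc3c(NCc4cccc(F)c4)ncnc32)[C@H](O)[C@@H]1O`, gives 15300 nM.
Compound 2, `Cc1cccc(CNc2ncnc3c2ncn3[C@@H]2O[C@H](CO)[C@@H](O)[C@H]2O)c1`, reaches only the limit of the assay, > 166000 nM, and no number.
Compound 3, `OC[C@H]1O[C@@H](n2cnc3c(NCc4ccc(Cl)c(Cl)c4)ncnc32)[C@H](O)[C@@H]1O`, gives 88800 nM.

Among these, compound 1 holds the lowest of the two numbers. Its nearest neighbour is reached by a 5.8-fold higher number from compound 1 to compound 3 (0.76 log units; beyond the scatter), a modest step. The other step from it, an at least 10-fold higher number from compound 1 to compound 2 (1.03 log units; beyond the scatter), is large and ends at the limit (the limit of > 166000 nM in this assay, at which 1 of the 3 values shown sits). Between the remaining pair the comparison reads an at least 1.8-fold lower number from compound 2 to compound 3 (0.27 log units; that floor lies within the scatter).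

Compound 4, `OC[C@H]1O[C@@H](n2cnc3c(NCc4ccc(F)cc4F)ncnc32)[C@H](O)[C@@H]1O`, has not yet been measured in this assay. It differs from compound 1 in one place: 2,4-difluorophenyl in place of 3-fluorophenyl on a saturated chain carbon bound to a nitrogen on an aromatic ring. Both measured changes at this place moved the number upward beyond the scatter, one exchanging fluoro for methyl, the other putting 3,4-dichlorophenyl in for 3-fluorophenyl. The new change keeps fluoro on the ring, now as 2,4-difluorophenyl instead of 3-fluorophenyl, a smaller departure from compound 1 than either measured one. A modest rise in this assay is therefore expected, probably smaller than the step to compound 3. The expected step is a 1.8-fold higher number from compound 1 to compound 4 (0.26 log units; within the scatter). Compound 4 is estimated at 28000 nM, within a range from 9000 nM to 90000 nM.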

Compound 4, half-maximal inhibitory concentration: > 166000 nM
Compound 4: no number, only a limit; the forecaster's own chance of this, stated with the estimate: 10%; middle value at least 5.9-fold (0.77 log units) from the limit.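

In this assay, fluoro on the ring turns out not to be enough to hold the level of compound 1: the change to 2,4-difluorophenyl gives an at least 10-fold higher number from compound 1 to compound 4 (1.03 log units; beyond the scatter), a step that ends at a limit rather than a number. This change looked like a small departure, yet compound 4 ends at the same limit as compound 2, and compound 1 keeps the lowest number among the compounds with a number at this place: the limit of > 166000 nM in this assay, at which 2 of the 4 values shown sit. The comparison with the dichlorinated ring reads an at least 1.8-fold higher number from compound 3 to compound 4 (0.27 log units; that floor lies within the scatter), a floor too small to rank that pair, and the step between the two compounds at the limit cannot be read.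

The compounds shown do not separate losing the fluoro of 3-fluorophenyl from gaining fluoro elsewhere on the ring, a question that a 2-fluorophenyl or a 4-fluorophenyl group would address. Whether any group at this place, such as plain phenyl or 3-chlorophenyl, can match or beat compound 1 also stays open, as does the reason for these losses.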